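From Amino to Carboxy: Expecting Compound 4's Cytotoxicity

The source may hold more compounds than are shown below. What is called first, only, known or untested is meant among the compounds shown, and "the series" means these compounds.

Of the compounds shown here, three sharing one core have been tested in a functional assay on HeLa cells (Homo sapiens) for cytotoxicity, read by neutral red uptake, with a stated time of 3 days; a lower number here means a stronger inhibitor, a higher number a weaker inhibitor. Compound 1 `Nc1ccc(-c2cc(=O)c3c(N)c(F)cc(F)c3o2)cc1F` gives > 100000 nM, a value that is a limit of the assay rather than a number. Compound 2 `CCCCc1c(F)c(N)c2c(=O)cc(-c3ccc(N)c(F)c3)oc2c1F`, which carries a butyl in place of hydrogen on an aromatic carbon, also gives > 100000 nM, again a limit. Compound 3 `Nc1ccc(-c2cc(=O)c3c(N)c(F)c(N)c(F)c3o2)cc1F` is the only one of the three with a measured number, 19000 nM. The two steps leading to it are an at least 5.2-fold lower number from compound 1 to compound 3 (0.72 log units; beyond the scatter) and an at least 5.2-fold lower number from compound 2 to compound 3 (0.72 log units; beyond the scatter), both showing that putting an amino on the core lowers the number; the step that the two limits leave unreadable from compound 1 to compound 2 tells nothing, because the limit of > 100000 nM in this assay, at which 2 of the 3 values shown sit, caps both of its values.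

Compound 4 `Nc1ccc(-c2cc(=O)c3c(N)c(F)c(C(=O)O)c(F)c3o2)cc1F` is not yet measured. It differs from compound 3 by carboxy in place of amino on an aromatic carbon. Going by the values given here, no measured step involves a carboxy, so the only guide is that the amino, now removed, was what gave compound 3 a measurable number at all. With that group gone and a carboxy in its place, compound 4 is expected to drift back toward the limit, a step of a 4.2-fold higher number from compound 3 to compound 4 (0.62 log units; beyond the scatter). The estimate for compound 4 is therefore 80000 nM, with a range from 20000 nM to 300000 nM.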

Compound 4, half-maximal inhibitory concentration: > 100000 nM
Compound 4: no number, only a limit; the forecaster's own chance of this, stated with the estimate: 50%; middle value at least 1.2-fold (0.09 log units) from the limit.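

In this assay, replacing the amino on this aromatic carbon, ortho to two fluoro groups, with a carboxy gives an at least 5.2-fold higher number from compound 3 to compound 4 (0.72 log units; beyond the scatter), so the change loses the measurable number. Hydrogen, butyl and now carboxy at this position all leave the compound at a limit of the assay rather than at a number, so amino is the only one of the four groups shown that gives a measured value, even though amino and carboxy are counted alike for hydrogen-bond donors and acceptors. The steps to compound 4 from compound 1 and from compound 2 cannot be read, because both ends of each step are limits: the limit of > 100000 nM in this assay, at which 3 of the 4 values shown sit.

Going by these compounds, how far these three compounds lie beyond the limit remains unknown, so hydrogen, butyl and carboxy cannot be ranked against one another. On these data alone, whether a methylamino or a hydroxy group on this carbon would also give a measurable number, or whether an amide in place of the carboxy would restore one, remains open.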